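A few compounds are considered here, and "the series" means these few. Any claim that something is new, unique, unknown or untested is made for them only; others in the source may bear on it.

Compound 1 `Nc1ccccc1NC(=O)CCCNCC(=O)Nc1cccc(Cl)c1`: 19500 nM
Compound 2 `Nc1ccccc1NC(=O)CCCNCC(=O)Nc1cccc([N+](=O)[O-])c1`: 15000 nM
Compound 3 `Nc1ccccc1NC(=O)c1ccc(NCC(=O)Nc2ccc([N+](=O)[O-])cc2)cc1`: 8200 nM

These three values come from a functional assay on U-251 cells (Homo sapiens) for inhibition, read by MTT assay, with a stated time of 2 days; a higher number here means a weaker inhibitor of growth, a lower number a stronger inhibitor of growth. There, compound 2 gives 15000 nM, which lies within the scatter of both compound 1 and compound 3. Those two outer compounds give 19500 nM for compound 1 and 8200 nM for compound 3.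

The next compound, compound 4 `Nc1ccccc1NC(=O)CCCNCC(=O)Nc1ccccc1Cl`, has 2-chlorophenyl in place of 3-nitrophenyl on an amide-type nitrogen. Within the data shown here, one measured step bears on this change, a 1.3-fold lower number from compound 1 to compound 2 (0.11 log units; within the scatter), and it stays within the scatter. It exchanges chloro and nitro on an otherwise unchanged structure. Among the measured compounds shown here, the data hold no measured step that changes where the chloro sits on the ring, so that part of the change remains untested. No shift beyond the scatter is therefore expected in this assay, and no direction can be favoured with confidence. The expected change is small, a 1.2-fold higher number from compound 2 to compound 4 (0.08 log units; within the scatter). For compound 4 the estimated value is 18000 nM, with an expected range from 9000 nM to 36000 nM.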

Compound 4, concentration for 50% growth inhibition: 28600 nM
The estimate for compound 4 lay 1.6-fold (0.20 log units) below the measured number; the measured number falls inside the stated range.
By their numbers in this assay, from the lowest: compounds 3, 2, 1 and 4 (each within the scatter of the next, the first and the last beyond it).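

When only the place of the chloro on the ring changes, this assay shows a 1.5-fold higher number from compound 1 to compound 4 (0.17 log units; within the scatter), the first measured test of where the chloro sits on the ring, and it gives no shift beyond the scatter. The exchange of 3-nitrophenyl for 2-chlorophenyl shows a 1.9-fold higher number from compound 2 to compound 4 (0.28 log units; within the scatter), so the three aromatic groups at this nitrogen are not told apart in these compounds. Nothing measured alongside these growth numbers offers an explanation for them.

The compounds shown leave open whether a group of another kind on this nitrogen, such as an aminophenyl, a carboxylic acid or a pyridine ring, would move the number beyond the scatter. Compound 3 differs from the other compounds in more than one place, so its number cannot be assigned to any single change.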